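Swapping the aryl group on the piperazine nitrogen

This account rests on a few compounds, and the source may have more. Where it says the series, first, only, none or still open, it means among the compounds named here.

Three compounds share a core in which a nitroimidazole-bearing chain is linked through a dithiocarbamate to a six-membered ring with two nitrogens. Compound 1 `CCOC(=O)N1CCN(C(=S)SCC(O)Cn2c([N+](=O)[O-])cnc2C)CC1` in a toxicity assay on HeLa cells (Homo sapiens) for cytotoxicity, read by MTT assay, with a stated time of 24 h (on this read-out higher numbers stand for weaker inhibition and lower numbers for stronger inhibition), gives 1610000 nM. Compound 2 `CCN1CCN(C(=S)SCC(O)Cn2c([N+](=O)[O-])cnc2C)CC1` gives only a limit, > 5000000 nM, which is the limit of > 5000000 nM in this assay, at which 1 of the 3 values shown sits. Compound 3 `Cc1ncc([N+](=O)[O-])n1CC(O)CSC(=S)N1CCN(c2ccccc2F)CC1` gives 3240000 nM. Among the two plain numbers compound 3 is the higher one, though the gap a 2.0-fold higher number from compound 1 to compound 3 (0.30 log units; within the scatter) is within the scatter, and the step of an at least 1.5-fold lower number from compound 2 to compound 3 (0.18 log units; that floor lies within the scatter) has a floor that is also within the scatter. The step of an at least 3.1-fold higher number from compound 1 to compound 2 (0.49 log units; beyond the scatter) is the only one beyond the scatter.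

Compound 4 `Cc1ncc([N+](=O)[O-])n1CC(O)CSC(=S)N1CCN(c2cccc(Cl)c2)CC1` differs from compound 3 in one place: 3-chlorophenyl in place of 2-fluorophenyl on an amine nitrogen in a ring. For the measured compounds named here, no measured step exchanges one aryl group for another on that ring nitrogen, so the only guidance is that the steps of a 2.0-fold higher number from compound 1 to compound 3 (0.30 log units; within the scatter) and an at least 1.5-fold lower number from compound 2 to compound 3 (0.18 log units; that floor lies within the scatter) leave compound 3 close to compound 1 and near the limit of compound 2. For compound 4 a step of a 1.0-fold lower number from compound 3 to compound 4 (0.01 log units; within the scatter) is therefore expected, that is, none beyond the scatter. Compound 4 is estimated at 3200000 nM, within 1200000 nM to 8000000 nM, with a real chance that only a limit is reported.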

Compound 4, half-maximal inhibitory concentration: 1080000 nM
The estimate for compound 4 lay 3.0-fold (0.47 log units) above the measured number, and the stated range ends above it.
By their numbers in this assay, from the lowest: compounds 4, 1 and 3 (each within the scatter of the next, the first and the last beyond it). At a limit, above all of these: compound 2.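

For the compounds shown here, this is the first step that exchanges one aryl group for another on the ring nitrogen, and in this assay it gives a 3.0-fold lower number from compound 3 to compound 4 (0.48 log units; beyond the scatter), so the choice of aryl group at this position can matter beyond the scatter. Placing 3-chlorophenyl instead of ethyl gives an at least 4.6-fold lower number from compound 2 to compound 4 (0.66 log units; beyond the scatter), a step beyond the scatter, whereas the floor of the step from ethyl to 2-fluorophenyl stayed within it; placing 3-chlorophenyl instead of ethoxycarbonyl gives a 1.5-fold lower number from compound 1 to compound 4 (0.17 log units; within the scatter), so these two groups cannot be told apart here. Compound 2 gives a limit and not a number, so its step to the 3-chlorophenyl compound has only a floor: the limit of > 5000000 nM in this assay, at which 1 of the 4 values shown sits.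

The two aryl groups differ both in the halogen and in its place on the ring, so the compounds shown cannot say which of these changes accounts for the step; 2-chlorophenyl and 3-fluorophenyl would separate the two. Going by these compounds, how an unsubstituted phenyl, or a phenyl carrying a methoxy group or an amine, would compare at this ring nitrogen also remains open.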